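Trimming an Allyl to Methyl on a Pyrazolidinone Core

The compounds below may be only part of what the source reports. "The series", "measured", "known", "first", "only" and "open" are said of these compounds alone.

Measured compounds:
- compound 1 `C=CCC1C(=C)C(=O)N(c2ccccc2)N1c1ccccc1`: 2730 nM
- compound 2 `C=C1CN(C)N(c2ccccc2)C1=O`: "not determined" (no result reported)
- compound 3 `C=C1C(=O)N(c2ccccc2)N(C)C1CC`: "not determined" (no result reported)

Going by the values given here, in an ADME assay on HUVEC cells (Homo sapiens) for inhibition, read by MTT assay, with a stated time of 48 h (a lower number here means a stronger inhibitor, a higher number a weaker inhibitor), compound 1 gives 2730 nM, the only number in this set. For compound 2 the entry reads "not determined" (no result reported), and for compound 3 it reads "not determined" (no result reported), so neither offers a point of comparison. Compound 4 `C=C1C(=O)N(c2ccccc2)N(c2ccccc2)C1C` has not been measured. It differs from compound 1 by hydrogen in place of vinyl on a saturated chain carbon bound to a saturated ring carbon; cut one bond further out, the allyl group becomes methyl. Among the compounds with values here, no measured pair shows what such a trimming does here, so the expectation rests on the small size of the change alone: a step of a 1.3-fold higher number from compound 1 to compound 4 (0.11 log units; within the scatter), hardly beyond the scatter, is expected. Compound 4 is estimated at 3500 nM, within 1500 nM to 8000 nM.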

Compound 4, half-maximal inhibitory concentration: 29900 nM
Compound 4: the middle estimate sits 8.5-fold (0.93 log units) below what was measured, outside the stated range (above it).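

Trimming the allyl group to methyl proves to be far from a minor edit: in this assay, the loss of the vinyl gives an 11-fold higher number from compound 1 to compound 4 (1.04 log units; beyond the scatter). This shows that the chain on this saturated ring carbon matters to the result, which compounds 2 and 3, with no numbers, could not show. The data offer no explanation for the rise.

Going by these compounds, whether the double bond or the chain length counts remains open. A propyl chain in the same place would separate the two, and a butyl chain would extend the comparison to a longer saturated chain.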